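The compounds below may be only part of what the source reports. "The series", "measured", "known", "first", "only" and "open" are said of these compounds alone.

Measured in a functional assay on A549 cells (Homo sapiens) for cytotoxicity, read by MTT assay, with a stated time of 48 h; on this read-out higher numbers stand for weaker inhibition and lower numbers for stronger inhibition:
- Compound 1 `COc1cc(O)ccc1C(=O)C[C@@H]1c2ccc(O)c(O)c2C[C@H]1C(C)(C)O`: 2200 nM
- Compound 2 `COc1cc(O)ccc1C(=O)C[C@H]1c2ccc(O)c(O)c2C[C@@H]1C(C)(C)O`: 2500 nM
- Compound 3 `COC(=O)C[C@@H]1c2c(-c3ccc(O)cc3OC)cc(O)c(O)c2C[C@@H]1C(C)(C)O`: 5600 nM

Compound 3, at 5600 nM, has the highest of the three numbers in this assay, and its gaps to compound 1 and compound 2 both lie beyond the scatter. Compound 4 `COC(=O)C[C@@H]1c2c(-c3ccc(O)cc3OC)cc(O)c(O)c2C[C@H]1C(C)(C)O` has not yet been measured. It relates to compound 3 as follows: the two compounds have the same atoms and bonds and differ only in configuration as drawn: 1 of 2 stereo elements differ; a stereocentre at a saturated ring carbon is drawn S in compound 3 and R in compound 4.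

For the measured compounds named here, only one measured step bears on this change: a 1.1-fold higher number from compound 1 to compound 2 (0.06 log units; within the scatter). That step concerns (the fact that compounds 1 and 2 differ only in the configuration as drawn), and it stays within the scatter. It is only a partial guide, since compounds 1 and 2 are mirror images with both stereo elements inverted, whereas here a single stereocentre differs. On this evidence, no shift beyond the scatter is expected in either direction. The expected change is small, at a 1.1-fold lower number from compound 3 to compound 4 (0.05 log units; within the scatter).

For compound 4 the estimated value is 5000 nM, with an expected range from 2400 nM to 10500 nM.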

Compound 4, half-maximal inhibitory concentration: 6000 nM
Beside the measured number, compound 4's estimate is 1.2-fold (0.08 log units) below it, within the range that was stated.
By their numbers in this assay, from the lowest: compounds 1 and 2 (each within the scatter of the next); then compounds 3 and 4 (each within the scatter of the next).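

In this assay, inverting one stereocentre at a saturated ring carbon gives a 1.1-fold higher number from compound 3 to compound 4 (0.03 log units; within the scatter). The earlier step, a 1.1-fold higher number from compound 1 to compound 2 (0.06 log units; within the scatter), came from a pair of mirror images, in which both stereo elements changed together and neither could be read alone. This pair separates a single stereocentre, with nothing else changing, and within this one pair its configuration as drawn moves the number no further than the scatter: the fact that compounds 3 and 4 differ only in the configuration as drawn.

Going by these compounds, what stays open is whether this stereocentre would count for as little if a carboxylic acid or an amide took the place of the ester in compound 3. Also open, on these data alone, is how the other stereocentre would behave if it alone were inverted on this core.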